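The compounds below may be only part of what the source reports. "The series", "measured", "known", "first", "only" and "open" are said of these compounds alone.

The measured compounds are:

compound 1 `CCCOC(=O)Nc1ccc([Se]C#N)cc1`, which in a functional assay on CCRF-CEM cells (Homo sapiens) for cytotoxicity, read by MTT assay, with a stated time of 72 h (a lower number here means a stronger inhibitor of growth, a higher number a weaker inhibitor of growth), gives 38400 nM
compound 2 `CCOC(=O)Nc1ccc([Se][Se]c2ccc(NC(=O)OCC)cc2)cc1`, which in this assay gives 49500 nM

Among the compounds with values here, compound 1 and compound 2 differ in more than one place, so no single step between them can be traced. Their two numbers lie within the usual scatter of each other, and neither can be called the stronger inhibitor of growth on this evidence. Compound 3 `N#C[Se]c1ccc(NC(=O)OCc2ccccc2)cc1` has not yet been measured. It differs from compound 1 by phenyl in place of ethyl on a saturated chain carbon bound to an oxygen next to a carbonyl group. Within the data shown here, no measured pair shows what such a change does in this assay, so the expectation rests on compound 1 alone: a step of modest size is expected, with no confident direction, and quite possibly none beyond the scatter. The number expected for compound 3 in this assay is 25000 nM, with a range from 8000 nM to 80000 nM. The step this estimate implies is expected to be a 1.5-fold lower number from compound 1 to compound 3 (0.19 log units; within the scatter).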

Compound 3, concentration for total growth inhibition: 48400 nM
Beside the measured number, compound 3's estimate is 1.9-fold (0.29 log units) below it; low and high end bracket the measured number.
By their numbers in this assay, from the lowest: compounds 1, 3 and 2 (each within the scatter of the next).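

Phenyl in place of ethyl on a saturated chain carbon bound to an oxygen next to a carbonyl group gives a 1.3-fold higher number from compound 1 to compound 3 (0.10 log units; within the scatter) in this assay as the first step traced at this position. The larger group, with its six-membered aromatic ring, therefore leaves the number within the scatter, so this change shows no clear effect on growth inhibition here. No measurement at hand offers an explanation for this result.

On these data alone, whether any group at this place can move the number beyond the scatter stays open, since an amine, a carboxylic acid or a longer chain might read differently. A single pair also cannot show whether phenyl in place of ethyl would read the same way on another core.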